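Swapping the iodoethenyl of compound 2 for a sulfinyl group

The source may hold more compounds than are shown below. What is called first, only, known or untested is meant among the compounds shown, and "the series" means these compounds.

Measured so far:
compound 1, `CO[C@@H]1OC(n2cc(F)c(=O)[nH]c2=O)[C@H](OC(C)=O)[C@@H](OC(C)=O)[C@H]1F`, 34000 nM
compound 2, `O=c1[nH]c(=O)n([C@H]2C[C@H](O)[C@@H](CO)O2)cc1/C=C/I`, 63900 nM
compound 3, `Nc1ncnc2c1nnn2C[C@H]1CCC[C@H]1CO`, > 200000 nM

All three compounds were tested in an ADME assay on L1210/0 cells (Mus musculus) for cytotoxicity, with a stated time of 48 h; a lower number here means a stronger inhibitor, a higher number a weaker inhibitor. Compound 3 gives no number there but only a limit, > 200000 nM; this is the limit of > 200000 nM in this assay, at which 1 of the 3 values shown sits. Of the two real numbers, compound 2 stands at the top, yet compound 1 sits within the usual scatter of it, so the two cannot be told apart on cytotoxicity.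

Compound 4, `C[S+]([O-])c1cn([C@H]2C[C@H](O)[C@@H](CO)O2)c(=O)[nH]c1=O`, has not been measured. It differs from compound 2 at one spot: a group of 3 heavy atoms (1 carbon, 1 oxygen, 1 sulfur; no ring) in place of a group of 3 heavy atoms (2 carbon, 1 iodine; no ring), on an aromatic carbon. The 2-iodoethenyl group leaves the aromatic carbon and a group of one carbon, one oxygen and one sulfur enters in its place; the rest of the structure is untouched.

Among the measured compounds shown here, no pair of measured compounds differing in a single place is available, so no measured step guides this change. Given that the two numbers shown are already weak and that compound 3 reaches only a limit, the expected step from compound 2 to compound 4 in this assay is a modest move toward a weaker inhibitor, of a size that may not exceed the scatter; that expected step is a 1.9-fold higher number from compound 2 to compound 4 (0.27 log units; within the scatter). Compound 4 is therefore estimated at 120000 nM. The expected range for compound 4 runs from 30000 nM to 400000 nM, with a fair chance that only a limit is reported.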

Compound 4, half-maximal inhibitory concentration: > 200000 nM
Compound 4: a limit, no number; the forecaster's own chance of this, stated with the estimate: 35%; middle value at least 1.6-fold (0.22 log units) away from the limit.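

In this assay, among the compounds shown here, this aromatic carbon, two atoms from the ring nitrogen, now has its first measured change, and the first comparison here between compounds that differ in one place: replacing the 2-iodoethenyl group with the group of one carbon, one oxygen and one sulfur gives an at least 3.1-fold higher number from compound 2 to compound 4 (0.49 log units; beyond the scatter) in the cytotoxicity read-out. The swap keeps the heavy-atom count of the group the same, yet the cytotoxicity of compound 2, already weak, is not kept, so at this position the count alone does not preserve the effect. Compound 4 gives a limit and not a number, so the step has a lower bound but no true size, and the result joins compound 3 at the top of the measurable range: the limit of > 200000 nM in this assay, at which 2 of the 4 values shown sit.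

A single swap cannot tell whether the result reflects losing the 2-iodoethenyl group or gaining the new one. An ethyl chain, a bromine atom or a carboxylic acid on the same aromatic carbon would help separate those two readings, and an amine there would extend the comparison further.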